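The compounds below may be only part of what the source reports. "The series", "measured", "known", "first", "only" and "open" are said of these compounds alone.

Measured so far:
compound 1, `CC(=O)N1N=C(c2ccco2)CC1c1ccc(Cl)cc1`, gives 39000 nM in a functional assay on PC-3 cells (Homo sapiens) for cytotoxicity, read by sulforhodamine B assay, with a stated time of 48 h; a lower number here means a stronger inhibitor, a higher number a weaker inhibitor.
compound 2, `O=CCN1N=C(c2ccc3ccccc3c2)CC1c1cccc([N+](=O)[O-])c1`, gives 2980 nM in this assay.

Of these two numbers, compound 2 has the lower one; compound 1 lies well beyond the usual scatter on the weaker side, and the two structures differ in several places at once, so no single change can be tied to that gap.

Compound 3, `O=CCN1N=C(c2ccc3ccccc3c2)CC1c1cccc(Cl)c1Cl`, has not yet been measured. It differs from compound 2 by one change: 2,3-dichlorophenyl in place of 3-nitrophenyl on a saturated ring carbon. Among the compounds with values here, no measured pair shows the effect of this exact swap, so the direction of the step is uncertain. In this assay compound 3 is expected to land close to compound 2, with a step of a 1.2-fold lower number from compound 2 to compound 3 (0.08 log units; within the scatter), not clearly beyond the scatter. The estimate for compound 3 is 2500 nM, with a likely range from 800 nM to 8000 nM.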

Compound 3, half-maximal inhibitory concentration: 17900 nM
For compound 3 the middle estimate is 7.2-fold (0.85 log units) below the measured one; measured number above the stated range.
By their numbers in this assay, from the lowest: compound 2; then compound 3; then compound 1.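

In this assay, the group on this saturated ring carbon clearly matters: with the rest of compound 2 kept, 2,3-dichlorophenyl in place of 3-nitrophenyl gives a 6.0-fold higher number from compound 2 to compound 3 (0.78 log units; beyond the scatter) and so a weaker inhibitor. Within the data shown here, this is the first comparison here that isolates one position, whereas compound 1 differs from compound 2 in several places at once. The group that leaves has 2 hydrogen-bond acceptors and the one that enters has 0, but no supporting measurement shows whether that difference or any other accounts for the step.

Among these compounds, with only two groups compared on this carbon, it remains open whether the weaker result follows the loss of the nitro group or the arrival of the two chlorines. A phenyl ring bearing one chlorine, an amine or a carboxylic acid would help separate these possibilities.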